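A few compounds are considered here, and "the series" means these few. Any claim that something is new, unique, unknown or untested is made for them only; others in the source may bear on it.

In an ADME assay (liver) for metabolic stability, with Liver microsome (Rattus norvegicus) as the target, read by LC-MS, using microsomes, with a stated time of 30 min, tested at 4 uM (a higher number here means that more of the compound is left, a lower number that less of the compound is left), compound 1 (`Cc1nc(N2CCN(C)CC2)c2nc(-c3ccccc3Cl)n(C3CC3)c2n1`) gives 44% and compound 2 (`Cc1nc(N2CCN(C)CC2)c2nc(-c3ccccc3C#N)n(C3CCOCC3)c2n1`) gives 21%. Compound 2 thus holds the lower of the two numbers, with a gap beyond the scatter. These two compounds differ in more than one place, so their gap isolates no single change. Compound 3 (`CCc1ccccc1-c1nc2c(N3CCN(C)CC3)nc(C)nc2n1C1CCOCC1`) carries ethyl in place of cyano on an aromatic carbon of compound 2: ethyl in place of cyano on an aromatic carbon. Within the data shown here, no measured pair covers this change. A modest downward move is expected, and the estimated a number 7 percentage points lower from compound 2 to compound 3 (within the scatter) may stay within the scatter. The estimate for compound 3 is 14%, with an expected range of 4% to 32%.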

Compound 3, percent of the compound remaining: 51%
Estimate against measurement, compound 3: 37 percentage points below; the whole stated range lies below it.
By their numbers in this assay, from the lowest: compound 2; then compounds 1 and 3 (each within the scatter of the next).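

In this assay, among these compounds, the change from 2-cyanophenyl to 2-ethylphenyl gives a number 30 percentage points higher from compound 2 to compound 3 (beyond the scatter) and is the first single-place comparison, since compound 1 and compound 2 differ in more than one place. It shows that this aromatic carbon, ortho to a large group, is a place where one substituent change moves the number beyond the scatter. No measured finding accounts for the step.

As far as these compounds go, whether the step is specific to ethyl remains open, as a methoxy group, a propyl chain or an amine at this carbon would test. Also open, from the compounds shown here alone, is whether the same change holds with the cyclopropyl group of compound 1 in place of the tetrahydropyranyl group.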